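Swapping the Pendant Aryl Group on a Shared Core

The source may report more compounds than this note shows. Statements on the series, on what has been measured and on what is new or still open speak of the compounds shown alone.

Three compounds have been measured in an ADME assay on microsomes from liver (Homo sapiens) for metabolic stability, tested at 2.5 uM; on this read-out higher numbers stand for fast clearance and lower numbers for slow clearance:

Compound 1 `O=S(=O)(c1ccc(F)c(Cl)c1)c1cnc2cc(F)ccc2c1-c1cccc(Cl)c1`: 0.66 mL/min
Compound 2 `Cc1ccc(S(=O)(=O)c2cnc3cc(F)ccc3c2-c2cccc(Cl)c2)cc1F`: 2.13 mL/min
Compound 3 `COc1cccc(S(=O)(=O)c2cnc3cc(F)ccc3c2-c2cccc(Cl)c2)c1`: 2.97 mL/min

Among these three numbers compound 1 stands lowest, so it is the slowest-cleared of the set. The two steps away from it are both beyond the scatter: a 3.2-fold higher number from compound 1 to compound 2 (0.51 log units; beyond the scatter) and a 4.5-fold higher number from compound 1 to compound 3 (0.65 log units; beyond the scatter). The step between the other two, a 1.4-fold higher number from compound 2 to compound 3 (0.14 log units; within the scatter), lies within the scatter, so those two cannot be ordered.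

Compound 4 `O=S(=O)(c1ccc(F)c(Cl)c1)c1cnc2cc(F)ccc2c1-c1ccc(F)cc1` has not yet been measured. It differs from compound 1 at a different place than the measured steps did: 4-fluorophenyl in place of 3-chlorophenyl on an aromatic carbon

Every measured step swapped the group on the sulfonyl sulfur, while this change swaps the group on the aromatic carbon of the shared core. Going by the values given here, no measured step therefore bears directly on it; the measured steps only show that a single aryl swap in this set has moved the number by a modest amount. With nothing pointing in either direction, a small rise is expected, a 1.5-fold higher number from compound 1 to compound 4 (0.18 log units; within the scatter), within the scatter. Compound 4 is estimated at 1 mL/min, with a range from 0.4 mL/min to 2.5 mL/min.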

Compound 4, intrinsic clearance in a liver preparation (reported as CLH), per the amount of preparation that the assay uses: 0.69 mL/min
Estimate against measurement, compound 4: 1.4-fold (0.16 log units) above; low and high end bracket the measured number.
By their numbers in this assay, from the lowest: compounds 1 and 4 (each within the scatter of the next); then compounds 2 and 3 (each within the scatter of the next).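

In this assay, going by these compounds alone, the first swap at the aromatic carbon of the shared core gives a 1.0-fold higher number from compound 1 to compound 4 (0.02 log units; within the scatter) and so cannot be told apart from no difference at all. This one swap alters both the halogen on the ring, chlorine for fluorine, and where it sits, yet compound 1 and compound 4 remain within the usual scatter of each other, whereas the swaps on the sulfonyl sulfur gave a 3.2-fold higher number from compound 1 to compound 2 (0.51 log units; beyond the scatter) and a 4.5-fold higher number from compound 1 to compound 3 (0.65 log units; beyond the scatter) on the same read-out. Nothing measured here offers a reason for this result.

The two parts of the swap also stay tangled, since a 3-fluorophenyl or a 4-chlorophenyl at this carbon would be needed to separate the identity of the halogen from its place on the ring, and the same swap on the 3-methoxyphenyl sulfone of compound 3 would test whether the result carries over to another sulfonyl group. Also open, from the compounds shown here alone, is how far this carbon tolerates something quite unlike a halogenated phenyl, such as a plain phenyl, a phenyl bearing an amine or a carboxylic acid, or a short alkyl chain.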